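The source may hold more compounds than are shown below. What is called first, only, known or untested is meant among the compounds shown, and "the series" means these compounds.

- Compound 1 `COc1cc(/C=C2\CN(S(=O)(=O)c3ccc(F)cc3)C/C(=C\c3cc(OC)c(OC)c(OC)c3)C2=O)cc(OC)c1OC`: 2220 nM
- Compound 2 `COc1cc(/C=C2\CN(S(=O)(=O)c3ccc(NC(C)=O)cc3)C/C(=C\c3cc(OC)c(OC)c(OC)c3)C2=O)cc(OC)c1OC`: 1900 nM
- Compound 3 `COc1cc(/C=C2\CN(S(=O)(=O)c3ccc(F)cc3)C/C(=C\c3cc(OC)c(OC)c(OC)c3)C2=O)cc(OC)c1`: 5200 nM

These values come from a functional assay on QGY-7703 cells (Homo sapiens) for cytotoxicity, read by MTT assay, with a stated time of 24 h; on this read-out lower numbers stand for stronger inhibition and higher numbers for weaker inhibition. Compound 2 and compound 1 lie within the scatter of each other, so they cannot be ranked, while compound 3 gives a higher number than either. Compound 4 `COc1cc(/C=C2\CN(S(=O)(=O)c3ccc(NC(C)=O)cc3)C/C(=C\c3ccccc3F)C2=O)cc(OC)c1OC` has not yet been measured. It differs from compound 2 at one place: 2-fluorophenyl in place of 3,4,5-trimethoxyphenyl on a double-bonded chain carbon bound to a double-bonded ring carbon. In words, 2-fluorophenyl stands in place of 3,4,5-trimethoxyphenyl on a double-bonded chain carbon bound to a double-bonded ring carbon.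

The closest guide is the swap of hydrogen in place of methoxy on an aromatic carbon, which gave a 2.3-fold higher number from compound 1 to compound 3 (0.37 log units; beyond the scatter), a modest step toward weaker inhibition. The swap of acetamido in place of fluoro on an aromatic carbon gave a 1.2-fold lower number from compound 1 to compound 2 (0.07 log units; within the scatter), but that change lies elsewhere in the molecule and says little about this one. Going by the values given here, the new change is larger than the methoxy step, since all the methoxy groups of that substituent leave and a fluorine enters, and no measured compound shows that combination. A higher number is therefore expected, though with wide uncertainty. The expected change is a 2.1-fold higher number from compound 2 to compound 4 (0.32 log units; beyond the scatter). Compound 4 is estimated at 4000 nM, with an expected range of 1300 nM to 12000 nM.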

Compound 4, half-maximal inhibitory concentration: 2680 nM
Estimate against measurement, compound 4: 1.5-fold (0.17 log units) above, and the stated range covers the measured number.
By their numbers in this assay, from the lowest: compounds 2, 1, 4 and 3 (each within the scatter of the next, the first and the last beyond it).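

In this assay, the exchange of 3,4,5-trimethoxyphenyl for 2-fluorophenyl on a double-bonded chain carbon bound to a double-bonded ring carbon gives a 1.4-fold higher number from compound 2 to compound 4 (0.15 log units; within the scatter), so the two compounds cannot be told apart. Going by these compounds alone, the earlier compounds all carried methoxy groups on both outer aromatic rings, and the one step that touched them, a 2.3-fold higher number from compound 1 to compound 3 (0.37 log units; beyond the scatter), left open whether the full set of methoxy groups was needed for this level of cell killing. In the setting of compound 4, with acetamido on the sulfonyl-bound ring, this position keeps its read-out without any of the three methoxy groups, although the aromatic ring itself stays in place in both compounds, so nothing yet shows what happens without it.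

Still open, on these data alone, is whether this tolerance extends to very different groups at the same carbon, such as a phenyl ring carrying a carboxylic acid or an amine, or a longer alkyl chain in place of the ring, and whether 2-fluorophenyl behaves the same way in the fluoro-bearing compound 1. No measurement accompanies these compounds that could explain the result.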